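Three aryl amide analogues at the cytotoxicity limit

A few compounds are considered here, and "the series" means these few. Any claim that something is new, unique, unknown or untested is made for them only; others in the source may bear on it.

Measured compounds:
compound 1 `Cc1ccc(S(=O)(=O)N[C@@H](CC(=O)NC(C)(C)C)C(=O)NCCNC(=O)c2c(O)cccc2F)cc1`: in an ADME assay on Karpas-1106P cells (Homo sapiens) for cytotoxicity (a higher number here means that more compound is needed for the effect, a lower number that less compound is needed), compound 1 gives > 11100 nM, a limit of the assay.
compound 2 `Cc1ccc(S(=O)(=O)N[C@@H](CC(=O)NC(C)(C)C)C(=O)NCCNC(=O)Nc2ccccc2)cc1`: in this assay compound 2 gives > 11100 nM, a limit of the assay.
compound 3 `Cc1ccc(S(=O)(=O)N[C@@H](CC(=O)NC(C)(C)C)C(=O)NCCNC(=O)c2ccccn2)cc1`: in this assay compound 3 gives > 11100 nM, a limit of the assay.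

Among the compounds with values here, compound 1 stands at the limit of this assay, and the same holds for every value so far (the limit of > 11100 nM in this assay, at which 3 of the 3 values shown sit). Compound 1 differs from compound 2 by an anilino in place of the 2-fluoro-6-hydroxyphenyl on the carbonyl carbon, and from compound 3 by a pyridin-2-yl at the same position; the corresponding steps are a step that the two limits leave unreadable from compound 1 to compound 2 and a step that the two limits leave unreadable from compound 1 to compound 3, and between compounds 2 and 3 the step is a step that the two limits leave unreadable from compound 2 to compound 3. None of these can be sized, so the series gives no readable direction for a change at this carbonyl.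

Compound 4 `C#Cc1cccc(C(=O)NCCNC(=O)[C@H](CC(=O)NC(C)(C)C)NS(=O)(=O)c2ccc(C)cc2)c1` carries the change (3-ethynylphenyl in place of 2-fluoro-6-hydroxyphenyl on a carbonyl carbon). The three aryl groups tried at this position all sit at the limit, and nothing in the measured steps points to an exit from it. Compound 4 is therefore expected to remain at or near the limit, with an estimate of 15000 nM (range 5000 nM to 50000 nM). The estimate implies a step that the limit leaves unreadable from compound 1 to compound 4, within the scatter.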

Compound 4, half-maximal effective concentration: > 11100 nM
Compound 4 gave a limit, no number; the forecaster's own chance of this, stated with the estimate: 85%; the middle value is on the limit's open side.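

The steps from compound 1, compound 2 and compound 3 to compound 4 cannot be read, as all four compounds stand at one limit: the limit of > 11100 nM in this assay, at which 4 of the 4 values shown sit.

The compounds shown leave open whether, in this assay, any change on this carbonyl carbon gives a readable value.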